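The source may report more compounds than this note shows. Statements on the series, on what has been measured and on what is new or still open speak of the compounds shown alone.

In a functional assay on HeLa cells (Homo sapiens) for antiproliferative activity, read by MTT assay, with a stated time of 48 h (on this read-out higher numbers stand for weaker inhibition and lower numbers for stronger inhibition), two compounds have numbers so far:

Compound 1 (`COc1ccc(N(C)c2ccnc(Cl)n2)cc1`) gives 917 nM
Compound 2 (`COc1ccc(N(C)c2cc(C)nc(C)n2)cc1`) gives 322 nM

Compound 2 holds the lower of the two numbers, and its gap to compound 1 lies beyond the usual scatter. Compound 3 (`COc1ccc(N(C)c2cc(C)nc(C)n2)cc1O`) puts hydroxy in place of hydrogen on an aromatic carbon of compound 2, ortho to a methoxy group and meta to a large group (hydroxy in place of hydrogen on an aromatic carbon). Within the data shown here, no measured pair shows this change, so only a modest, uncertain gain in this assay is expected. The expected move is a 1.8-fold lower number from compound 2 to compound 3 (0.25 log units; within the scatter), toward stronger inhibition. Compound 3 is estimated at 180 nM, with an expected range from 40 nM to 800 nM.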

Compound 3, half-maximal inhibitory concentration: 93 nM
Compound 3: the middle estimate sits 1.9-fold (0.29 log units) above what was measured; measured number inside the range.
By their numbers in this assay, from the lowest: compound 3; then compound 2; then compound 1.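

Compounds 1 and 2 both carry hydrogen on this aromatic carbon, so neither could show what a group there does. In this assay hydroxy on this carbon, ortho to a methoxy group and meta to a large group, gives a 3.5-fold lower number from compound 2 to compound 3 (0.54 log units; beyond the scatter) and so shows that this position can respond to a single added oxygen. Nothing available bears on why the number falls.

From the compounds shown here alone, it remains open whether an amine, a fluorine or a second methoxy group on this carbon would move the number the same way. Going by these compounds, whether the step would hold on the core of compound 1 is also open.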